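Sulfonamide nitrogen substitution in a squalene monooxygenase series

A few compounds are considered here, and "the series" means these few. Any claim that something is new, unique, unknown or untested is made for them only; others in the source may bear on it.

Measured so far:
compound 1 `CCN(C/C=C/C#CC(C)(C)C)Cc1cccc(OCCNS(=O)(=O)c2cccs2)c1`: 450 nM
compound 2 `CCN(C/C=C/C#CC(C)(C)C)Cc1cccc(OCCN(CC)S(=O)(=O)c2cccs2)c1`: 90 nM
compound 3 `CCCN(CCOc1cccc(CN(CC)C/C=C/C#CC(C)(C)C)c1)S(=O)(=O)c1cccs1`: 170 nM

All three have been read in a functional assay on HepG2 cells for inhibition of squalene monooxygenase (Homo sapiens); on this read-out higher numbers stand for weaker inhibition and lower numbers for stronger inhibition. Compound 3 stands second highest of the three numbers. Its nearer neighbour is separated by a 1.9-fold higher number from compound 2 to compound 3 (0.28 log units; within the scatter), a gap within the scatter; the further one by a 2.6-fold lower number from compound 1 to compound 3 (0.42 log units; beyond the scatter), beyond it.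

Compound 4 `CCN(C/C=C/C#CC(C)(C)C)Cc1cccc(OCCN(C2CC2)S(=O)(=O)c2cccs2)c1` is not yet measured. Against compound 3 it carries cyclopropyl in place of propyl on a sulfonamide nitrogen; the incoming group differs from the outgoing one only in closing a three-membered non-aromatic ring of carbon only, with no change in donors, acceptors or charge.

Going by the values given here, three measured steps touch this position. a 5.0-fold lower number from compound 1 to compound 2 (0.70 log units; beyond the scatter) and a 2.6-fold lower number from compound 1 to compound 3 (0.42 log units; beyond the scatter) show that a carbon substituent in place of hydrogen on the sulfonamide nitrogen gives a modestly lower number; a 1.9-fold higher number from compound 2 to compound 3 (0.28 log units; within the scatter) shows that lengthening that substituent by one carbon makes no difference beyond the scatter. Among the compounds with values here, no measured step exchanges an open chain for a ring, so the cyclopropyl case rests on this analogy alone. A substituted sulfonamide nitrogen is retained, and the step is expected to stay within the scatter: a 1.1-fold lower number from compound 3 to compound 4 (0.05 log units; within the scatter).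

For compound 4 the expected value is 150 nM, with a range from 60 nM to 400 nM.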

Compound 4, half-maximal inhibitory concentration: 230 nM
Compound 4: the middle estimate sits 1.5-fold (0.19 log units) below what was measured; the range from low to high includes it.
By their numbers in this assay, from the lowest: compounds 2, 3, 4 and 1 (each within the scatter of the next, the first and the last beyond it).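

On this assay the exchanges of an open chain for a ring on the sulfonamide nitrogen read differently depending on the chain replaced: a 1.4-fold higher number from compound 3 to compound 4 (0.13 log units; within the scatter) leaves cyclopropyl within the scatter of propyl, whereas a 2.6-fold higher number from compound 2 to compound 4 (0.41 log units; beyond the scatter) sets it beyond the scatter from ethyl, a modest step towards weaker inhibition. Against hydrogen on the same nitrogen, a 2.0-fold lower number from compound 1 to compound 4 (0.29 log units; within the scatter) also stays within the scatter, so cyclopropyl does not separate from the unsubstituted sulfonamide as ethyl and propyl do, and the benefit seen with compound 2 and compound 3 cannot be claimed for every carbon substituent at this position. No available evidence bears on the reason for this reading.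

From the compounds shown here alone, it remains open whether a larger ring such as cyclobutyl, a branched group such as isopropyl or a smaller group such as methyl would sit with ethyl, or with cyclopropyl and hydrogen. Also open, going by these compounds, is how a chain ending in a hydroxyl or an amine would read on this nitrogen.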